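Series notes: the step from compound 3 to compound 4

The source may report more compounds than this note shows. Statements on the series, on what has been measured and on what is new or still open speak of the compounds shown alone.

Compound 1 `CC(C)(C)NC(=O)COC(=O)c1ccc([N+](=O)[O-])o1`: > 100000 nM, a limit of the assay.
Compound 2 `O=C(COC(=O)c1ccc([N+](=O)[O-])o1)NCC1CCCO1`: > 100000 nM, a limit of the assay.
Compound 3 `CC(C)(C)N(CCCc1ccccc1)C(=O)COC(=O)c1ccc([N+](=O)[O-])o1`: "not active" (no number reported), with no number reported.

All three entries come from an ADME assay on HEK-293T cells (Homo sapiens) for cytotoxicity, read by MTT assay, with a stated time of 3 days; a higher number here means that more compound is tolerated, a lower number that less compound is tolerated. Within the data shown here, the series so far stands at the limit of > 100000 nM in this assay, at which 2 of the 3 values shown sit. Compound 3 has no single number and is recorded only as "not active" (no number reported), so it offers no numerical starting point for the next step.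

The change to compound 4 `CC(C)(C)N(Cc1cccc([N+](=O)[O-])c1)C(=O)COC(=O)c1ccc([N+](=O)[O-])o1` is 3-nitrophenyl in place of phenethyl on a saturated chain carbon bound to an amide-type nitrogen. In short, 3-nitrophenyl takes the place of phenethyl on a saturated chain carbon bound to an amide-type nitrogen.

Among the measured compounds shown here, only one measured step is available, a step that the two limits leave unreadable from compound 1 to compound 2. It involves a different change, (oxolan-2-yl)methyl in place of tert-butyl on an amide-type nitrogen, and gives no readable size. For the measured compounds named here, no measured step therefore tests the exchange of phenethyl for 3-nitrophenyl, and no step of a particular size or direction can be derived for this assay. The working expectation is that compound 4 stays in the same region as the rest of the series, given (the limit of > 100000 nM in this assay, at which 2 of the 3 values shown sit), and that the assay most likely reports a limit again. For compound 4 the estimated value is 100000 nM, with an expected range of 30000 nM to 150000 nM.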

Compound 4, half-maximal cytotoxic concentration: 78000 nM
The estimate for compound 4 lay 1.3-fold (0.11 log units) above the measured number; low and high end bracket the measured number.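

In this assay compound 3 is recorded as "not active" (no number reported) and compound 4 gives 78000 nM with no readable step between the two compounds. The compounds shown leave open how far 3-nitrophenyl in place of phenethyl, on a saturated chain carbon bound to an amide-type nitrogen, shifts the tolerated concentration.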